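Bromo to fluoro on the aromatic ring of the oxazoline ethers

The source may hold more compounds than are shown below. What is called first, only, known or untested is meant among the compounds shown, and "the series" means these compounds.

The series is followed in a toxicity assay on the whole organism with Rattus norvegicus as the target, at a dose of 400 mg/kg by the oral route; on this read-out lower numbers stand for a weaker effect and higher numbers for a stronger effect at the one dose given. Compound 1, `Brc1ccccc1OCC1=NCCO1`, gives 100% in this assay. Compound 2, `O=[N+]([O-])c1ccc(OCC2=NCCO2)cc1`, gives 100% in this assay. Compound 1 stands level with compound 2 at the digits recorded, the two values lying within the scatter of each other, so no order between them can be stated. Among the measured compounds shown here, no step between measured compounds that differ in one place is available, and no repeat of any change on this core exists among the measured pair.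

Compound 3, `Fc1ccccc1OCC1=NCCO1`, remains to be measured in this assay. It differs from compound 1 as follows: fluoro in place of bromo on an aromatic carbon. Since both measured compounds sit at the top of the read-out, little movement beyond the scatter is expected; a step from compound 1 to compound 3 of about a number 10 percentage points lower from compound 1 to compound 3 (within the scatter) is estimated, in the weaker direction if any. Compound 3 is expected to give about 90% in this assay, between 60% and 100%.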

Compound 3, a percentage reported as activity, at one dose (the size of the read-out at that dose, not a potency): 80%
Compound 3: middle estimate off by 10 percentage points, on the high side, within the range that was stated.
By their numbers in this assay, from the lowest: compound 3; then compounds 1 and 2 (each within the scatter of the next).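

In this assay, among the compounds shown here, the exchange of bromo for fluoro on an aromatic carbon gives the first readable step on this core, a number 20 percentage points lower from compound 1 to compound 3 (beyond the scatter) and beyond the scatter, so the read-out at this position is not indifferent to which halogen sits there. For the compounds shown here, the two earlier compounds offered no step between compounds differing in one place, and so could not show this; the present step is modest and rests on this single pair. Nothing at hand bears on why the read-out falls with this exchange.

As far as these compounds go, whether chloro or methyl at this place would stay with compound 1 or fall with compound 3 remains open. Also open, from the compounds shown here alone, are the effect of an amine or a longer chain here, and whether the same exchange at another ring carbon gives a step of like size.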